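The source may hold more compounds than are shown below. What is called first, only, known or untested is meant among the compounds shown, and "the series" means these compounds.

Two members of this series have so far been run in a functional assay on A549 cells (Homo sapiens) for cytotoxicity, read by XTT assay, with a stated time of 72 h; a higher number here means a weaker inhibitor, a lower number a stronger inhibitor. Going by the values given here, compound 1 `COc1ccc(C(O)c2ccc3c(ccn3C)c2)c(OC)c1OC` is the first of them; in this assay compound 1 reaches only the limit of > 10000 nM. Compound 2 `COc1ccc(/C(=N\OC(C)=O)c2ccc3c(ccn3C)c2)c(OC)c1OC` carries an acetoxy group on the double-bonded nitrogen; in this assay compound 2 likewise reaches only the limit of > 10000 nM. Among the compounds with values here, compound 2 therefore stands at the limit of > 10000 nM in this assay, at which 2 of the 2 values shown sit, and no step between measured compounds is available to draw on.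

Compound 3 `CN/N=C(/c1ccc2c(ccn2C)c1)c1ccc(OC)c(OC)c1OC` is the next candidate. Its change from compound 2 is methylamino in place of acetoxy on a double-bonded nitrogen; in words, methylamino in place of acetoxy on a double-bonded nitrogen. Within the data shown here, with both measured compounds sitting at the limit, there is no measured step to set a direction, and nothing among the numbers points to a gain beyond the usual scatter. The working expectation for compound 3 is that this assay again returns a limit rather than a number. The step from compound 2 to compound 3 is accordingly expected to be a step that the limit leaves unreadable from compound 2 to compound 3, none beyond the scatter. Compound 3 is estimated at 20000 nM, with a range of 6000 nM to 60000 nM.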

Compound 3, half-maximal inhibitory concentration: > 10000 nM
Compound 3: only a limit was reported (the forecaster's own chance of this, stated with the estimate: 70%); the middle value is on the limit's open side.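

Compound 2 and compound 3 both give only limits in this assay, so no step between them can be read: the limit of > 10000 nM in this assay, at which 3 of the 3 values shown sit.

The compounds shown leave open whether any member of this series gives a number in this assay, and how the values of compound 1, compound 2 and compound 3 stand relative to one another.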